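Removing the chloro group from compound 2: an expected gain

This account rests on a few compounds, and the source may have more. Where it says the series, first, only, none or still open, it means among the compounds named here.

Of the compounds shown here, two sharing one core have been measured in an assay on HEK293 cells for displacement of a labelled ligand from Neuronal acetylcholine receptor; alpha3/beta4 (Homo sapiens); on this read-out higher numbers stand for weaker inhibition and lower numbers for stronger inhibition. Compound 1 `COc1ccc(Nc2cncc(N3CC4CC(C3)N4)c2)cc1` gives 2.2 nM in this assay, and compound 2 `Clc1cccc(Nc2cncc(N3CC4CC(C3)N4)c2)c1` gives 293 nM. Within the data shown here, compound 2 therefore stands at the highest of the two numbers, with compound 1 as its only neighbour showing a far lower number, a gap well beyond the usual scatter. Compound 3 `c1ccc(Nc2cncc(N3CC4CC(C3)N4)c2)cc1` has not yet been measured. It differs from compound 2 by hydrogen in place of chloro on an aromatic carbon, on an aromatic carbon of a six-membered aromatic ring of carbon only, meta to a large group. Among the measured compounds shown here, no measured pair shows this exact change, so its effect can only be estimated from the two values above. Since compound 2 gives 293 nM while compound 1 gives 2.2 nM, the expectation is that compound 3 will move toward lower numbers, by a step of roughly a 9.8-fold lower number from compound 2 to compound 3 (0.99 log units; beyond the scatter). Compound 3 is therefore estimated at 30 nM, with a likely range from 5 nM to 150 nM.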

Compound 3, inhibition constant: 0.799 nM
The estimate for compound 3 lay 38-fold (1.57 log units) above the measured number; measured number outside the range, below it.
By their numbers in this assay, from the lowest: compound 3; then compound 1; then compound 2.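

In this assay, replacing 3-chlorophenyl with phenyl gives a 370-fold lower number from compound 2 to compound 3 (2.56 log units; beyond the scatter), so the chloro group at this place carries a far larger penalty than the earlier values suggested. Hydrogen in place of methoxy also gives a 2.8-fold lower number from compound 1 to compound 3 (0.44 log units; beyond the scatter), a modest step, which leaves compound 3, with its plain phenyl ring, at the lowest number of the three and shows that this ring needs neither group to reach that level. Nothing available explains why the chloro group costs so much.

Going by these compounds, it remains open whether this penalty is specific to chloro or would also follow a fluoro or methyl group on the same aromatic carbon, meta to a large group. An amine at that place could show whether any group there is poorly tolerated.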